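A few compounds are considered here, and "the series" means these few. Any claim that something is new, unique, unknown or untested is made for them only; others in the source may bear on it.

Measured compounds:
- compound 1 `Cn1cnc2c(N3CCCCC3)nc(-c3ccccc3O)nc21`: 30.2%
- compound 2 `CN1CCN(c2nc(-c3ccccc3O)nc3c2ncn3C)CC1`: 36%

In an assay on cells for displacement of a labelled ligand from adenosine receptor A2b (Homo sapiens), read by scintillation counting and radioligand binding, with a stated time of 30 min, tested at 10 uM (a lower number here means less inhibition, a higher number more inhibition at the concentration tested (going by the name of the read-out)), compound 1 gives 30.2%. Compound 2 gives 36% in this assay. Of the two numbers, compound 1 has the smaller, but the step of a number 5.8 percentage points higher from compound 1 to compound 2 (within the scatter) is within the scatter, so the two compounds cannot be told apart on this evidence.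

Compound 3 `Cn1cnc2c(N3CCCCC3)nc(-c3ccccc3Cl)nc21` has not yet been measured. It differs from compound 1 in a single place: chloro in place of hydroxy on an aromatic carbon. Among the measured compounds shown here, none of the measured steps bears on this change. For the measured compounds named here, the only step so far, a number 5.8 percentage points higher from compound 1 to compound 2 (within the scatter), alters a different group on a different part of the shared core and leaves the hydroxy group in place, so it says nothing about swapping hydroxy for chloro. With no relevant comparison, no step beyond the scatter can be expected in either direction.

The estimate for compound 3 is therefore 30%, with a range from 8% to 55%. That estimate means an expected step of a number 0.2 percentage points lower from compound 1 to compound 3 (within the scatter), a wide range reflecting the absence of any guiding data.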

Compound 3, a percentage reported as inhibition, at one concentration (the size of the read-out at that concentration, not a potency): 32.7%
For compound 3 the middle estimate is 2.7 percentage points below the measured one; measured number inside the range.
By their numbers in this assay, from the lowest: compounds 1, 3 and 2 (each within the scatter of the next).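

In this assay the swap of hydroxy for chloro gives a number 2.5 percentage points higher from compound 1 to compound 3 (within the scatter) and so cannot be told apart from no change on this evidence. The earlier compounds shown here all carried the hydroxy group, so they could not show what happens when it leaves this place, on an aromatic carbon ortho to a large group. The result now shows that 2-chlorophenyl, whose chloro counts no hydrogen-bond donor or acceptor, gives a number that cannot be separated from that of 2-hydroxyphenyl, whose hydroxy counts one of each, although no information bears on what lies behind this result.

On these data alone, what a methoxy group, an amine or a carboxylic acid would give at this same place remains open, as does whether chloro in place of hydroxy would give a similar result with the 4-methylpiperazin-1-yl group of compound 2 on the shared core. As far as these compounds go, each number also comes from a single tested concentration and is not a potency, so any smaller difference in potency between these compounds remains unknown.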